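Carbamate variation on a sulfonate warhead series: compound 4

This account rests on a few compounds, and the source may have more. Where it says the series, first, only, none or still open, it means among the compounds named here.

Measured compounds in a toxicity assay on Huh-7 cells (Homo sapiens) for cytotoxicity; on this read-out lower numbers stand for higher toxicity in this test and higher numbers for lower toxicity in this test:
compound 1 `CCCCC1CCC(OC(=O)N[C@@H](CC(C)C)C(=O)N[C@@H](C[C@@H]2CCNC2=O)C(O)S(=O)(=O)O)CC1` gives 59100 nM;
compound 2 `CCCC1CCC(OC(=O)N[C@@H](CC(C)C)C(=O)N[C@@H](C[C@@H]2CCNC2=O)C(O)S(=O)(=O)O)CC1` gives a value reported only as a limit of the assay, > 100000 nM;
compound 3 `CC(C)C[C@H](NC(=O)OCC1CCC(F)(F)CC1)C(=O)N[C@@H](C[C@@H]1CCNC1=O)C(O)S(=O)(=O)O` gives a value reported only as a limit of the assay, > 100000 nM.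

Compound 3 therefore stands at the limit of this assay; the same limit, (the limit of > 100000 nM in this assay, at which 2 of the 3 values shown sit), also covers compound 2, so compound 3 cannot be placed against compound 2 at all, and the step that the two limits leave unreadable from compound 2 to compound 3 stays unreadable. Against compound 1 the step of an at least 1.6-fold higher number from compound 1 to compound 3 (0.22 log units; that floor lies within the scatter) is read only as a floor that lies within the scatter.

Compound 4 `CC(C)C[C@H](NC(=O)OC1CCCCC1)C(=O)N[C@@H](C[C@@H]1CCNC1=O)C(O)S(=O)(=O)O` differs from compound 3 as follows: cyclohexyl in place of (4,4-difluorocyclohexyl)methyl on an oxygen next to a carbonyl group. The nearest measured steps both end at the limit: an at least 1.6-fold higher number from compound 1 to compound 2 (0.22 log units; that floor lies within the scatter) and an at least 1.6-fold higher number from compound 1 to compound 3 (0.22 log units; that floor lies within the scatter). Neither shows movement beyond the scatter, and none of the shown steps leaves the group on the oxygen next to the carbonyl group with a readable size.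

Within the data shown here, with compound 3 already at the limit and no step on this carbamate position resolved beyond the scatter, compound 4 is expected to show no step beyond the scatter, a number no higher from compound 3 to compound 4 (the limit leaves the size open), and will most likely again be reported as a limit. The estimate for compound 4 in this assay is 100000 nM, with a range from 50000 nM to 200000 nM.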

Compound 4, half-maximal cytotoxic concentration: > 100000 nM
Compound 4 gave a limit, no number; the forecaster's own chance of this, stated with the estimate: 65%; the middle value lies on the limit itself.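

In this assay compound 4, with a plain cyclohexyl on the oxygen, gives > 100000 nM, a limit of the assay and not a number. Among these compounds, the one readable new step, an at least 1.6-fold higher number from compound 1 to compound 4 (0.22 log units; that floor lies within the scatter), replaces butyl on a saturated ring carbon with hydrogen but gives only a floor, and the steps that end at compound 4 from compound 2 and compound 3 cannot be read. This position now holds three different groups at the same limit, 4-propylcyclohexyl, (4,4-difluorocyclohexyl)methyl and cyclohexyl, so the limit is reached here even with no substituent on the ring: the limit of > 100000 nM in this assay, at which 3 of the 4 values shown sit.

Any differences among compound 2, compound 3 and compound 4 remain hidden behind the limit, and compound 1 alone gives a number, so the butyl group cannot be tied to a real change in this read-out. From the compounds shown here alone, how this assay would respond to an amine or a carboxylic acid on the cyclohexyl ring, or to a chain longer than butyl, remains open.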